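Compound 3 Expected to Be Better Tolerated Than Compound 1

The source may hold more compounds than are shown below. What is called first, only, known or untested is meant among the compounds shown, and "the series" means these compounds.

Compound 1 `O=C(CSc1nncnc1-c1ccccc1Cl)c1ccc(Br)cc1Br` gives 28000 nM in an ADME assay on MT4 cells (Homo sapiens) for cytotoxicity, read by MTT assay (a lower number here means that less compound is tolerated, a higher number that more compound is tolerated), the lowest of the two numbers recorded. Compound 2 `O=C(CSc1nncnc1-c1cccc2ccccc12)Nc1ccccc1Br` gives 87000 nM in this assay, which stands beyond the usual scatter from the number of compound 1. Compound 3 `O=C(CSc1nncnc1-c1ccccc1Cl)Nc1ccccc1Cl` has not yet been measured; it differs from compound 1 by (2-chlorophenyl)amino in place of 2,4-dibromophenyl on a carbonyl carbon. Because compound 2 gives 87000 nM, an upward step beyond the scatter is expected for compound 3. The expected step in this assay is a 2.1-fold higher number from compound 1 to compound 3 (0.33 log units; beyond the scatter). Compound 3 is estimated at 60000 nM, within a range from 25000 nM to 150000 nM.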

Compound 3, half-maximal cytotoxic concentration: 90000 nM
Compound 3: middle estimate off by 1.5-fold (0.18 log units), on the low side; the measured number falls inside the stated range.
By their numbers in this assay, from the lowest: compound 1; then compounds 2 and 3 (each within the scatter of the next).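

In this assay the exchange of 2,4-dibromophenyl for (2-chlorophenyl)amino on the carbonyl carbon gives a 3.2-fold higher number from compound 1 to compound 3 (0.51 log units; beyond the scatter) with the heavy-atom count unchanged and one hydrogen-bond donor added. Among these compounds, the earlier compounds differed in more than one place, so this is the first reading of a single change, here at this position on the core of compound 1. No measured evidence accounts for the step.

The change brings in the nitrogen and swaps the halogens at once, so the compounds shown cannot separate the two. From the compounds shown here alone, whether an unsubstituted phenylamino or a morpholine at this position would give a similar number remains open.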